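A few compounds are considered here, and "the series" means these few. Any claim that something is new, unique, unknown or untested is made for them only; others in the source may bear on it.

Measured compounds:
compound 1 `O=C(Nc1cc(Sc2ncn[nH]2)c(O)c2ccccc12)c1ccc2ccccc2c1` 41.6%
compound 2 `O=C(Nc1cc(Sc2nncs2)c(O)c2ccccc12)c1ccc(Cl)cc1` 7.5%

In an assay on isolated protein for inhibition of RAC-alpha serine/threonine-protein kinase (Homo sapiens), read by fluorescence, with a stated time of 30 min, tested at 10 uM (a higher number here means more inhibition at the concentration tested (going by the name of the read-out), a lower number less inhibition), compound 2 gives the lowest of the two numbers shown; its nearest neighbour, compound 1, gives a value higher by a margin beyond the scatter. Within the data shown here, compound 1 and compound 2 differ in two places, so no single step between them is known. Compound 3 `O=C(Nc1cc(Sc2ncn[nH]2)c(O)c2ccccc12)c1ccc(Cl)cc1` is not yet measured; it differs from compound 2 in one place: 1H-1,2,4-triazol-5-yl in place of 1,3,4-thiadiazol-2-yl on a sulfur. Compound 3 shares this triazole with compound 1, so an upward step is expected, a number 12.5 percentage points higher from compound 2 to compound 3 (beyond the scatter), though perhaps no larger than the scatter. For compound 3 the estimate in this assay is 20%, between 5% and 40%.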

Compound 3, a percentage reported as inhibition, at one concentration (the size of the read-out at that concentration, not a potency): 50.1%
The estimate for compound 3 lay 30.1 percentage points below the measured number; measured number outside the range, above it.
By their numbers in this assay, from the lowest: compound 2; then compounds 1 and 3 (each within the scatter of the next).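

In this assay, with 4-chlorophenyl held on the carbonyl carbon, the group on the sulfur proves decisive: 1H-1,2,4-triazol-5-yl in place of 1,3,4-thiadiazol-2-yl gives a number 42.6 percentage points higher from compound 2 to compound 3 (beyond the scatter). With the triazole held, 4-chlorophenyl in place of naphthalen-2-yl on a carbonyl carbon gives a number 8.5 percentage points higher from compound 1 to compound 3 (within the scatter), so these two groups cannot be told apart here. Nothing at hand explains the step on the sulfur. Still open, on these data alone, is whether a carboxylic acid or an amine on the sulfur would match the triazole. Also open, as far as these compounds go, is whether the same step between the two rings would appear with naphthalen-2-yl on the carbonyl carbon.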